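Cyclopropyl in place of isopropyl on compound 3

The compounds below may be only part of what the source reports. "The series", "measured", "known", "first", "only" and "open" are said of these compounds alone.

Results in a functional assay on Huh-7 cells (Homo sapiens) for cytotoxicity, read by MTT assay, with a stated time of 72 h (on this read-out lower numbers stand for higher toxicity in this test and higher numbers for lower toxicity in this test), follow, and each one is a limit rather than a number
Compound 1 `CCCS(=O)(=O)N1CCC2(CC1)OOC(C)(CC)OO2` gives > 100 ug/mL as a limit
Compound 2 `CCCC1(C)OOC2(CCN(S(=O)(=O)CCC)CC2)OO1` gives > 100 ug/mL as a limit
Compound 3 `CCCS(=O)(=O)N1CCC2(CC1)OOC(C)(C(C)C)OO2` gives > 100 ug/mL as a limit

For the measured compounds named here, the series so far shows the limit of > 100 ug/mL in this assay, at which 3 of the 3 values shown sit, and so offers no number to rank. As far as these compounds go, compound 3 therefore stands only at a limit, like both of its relatives, and its true value is unknown.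

Compound 4 `CCCS(=O)(=O)N1CCC2(CC1)OOC(C)(C1CC1)OO2` keeps the shared core of compound 3 and changes one group, cyclopropyl in place of isopropyl on a saturated ring carbon in the same spot.

Going by the values given here, three measured steps bear on this change. The closest is a step that the two limits leave unreadable from compound 2 to compound 3 and it also swaps the group on that ring carbon. The other two are a step that the two limits leave unreadable from compound 1 to compound 2 and a step that the two limits leave unreadable from compound 1 to compound 3 and they alter the same chain. None of them has a size that can be read. With the step that the two limits leave unreadable from compound 2 to compound 3 as the nearest guide, no step beyond the usual scatter and no direction is expected in this assay for the new group.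

The expected change is a step that the limit leaves unreadable from compound 3 to compound 4 and a further limit is the likeliest report.

For compound 4 the estimated value is 130 ug/mL with an expected range from 60 ug/mL to 300 ug/mL in this test.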

Compound 4, half-maximal cytotoxic concentration: > 100 ug/mL
Compound 4 ended at the assay's limit; the forecaster's own chance of this, stated with the estimate: 85%; the middle value is on the limit's open side.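

In this assay, for the compounds shown here, compound 4 gives > 100 ug/mL as a limit and not a number, so no step linking it to compound 1, compound 2 or compound 3 can be read. The compounds shown leave open how their true values compare and whether the group on this ring carbon matters for toxicity in this test, as the series rests on one limit: the limit of > 100 ug/mL in this assay, at which 4 of the 4 values shown sit.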